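A few compounds are considered here, and "the series" means these few. Any claim that something is new, unique, unknown or untested is made for them only; others in the source may bear on it.

Measured so far in a functional assay on MCF7 cells (Homo sapiens) for antiproliferative activity, read by MTT assay, with a stated time of 48 h; a lower number here means a stronger inhibitor, a higher number a weaker inhibitor:
compound 1 `COc1ccc(C(=O)c2ccc(OC)c3c2C=CC(C)(C)O3)c(NC(=O)CO)c1`: 940 nM
compound 2 `COc1ccc(C(=O)c2ccc(OC)c3c2C=CC(C)(C)O3)c(NC(=O)CN)c1`: 1250 nM

Compound 2, at 1250 nM, cannot be separated from compound 1. Within the data shown here, the only measured step is a 1.3-fold higher number from compound 1 to compound 2 (0.12 log units; within the scatter), with amino in place of hydroxy on a saturated chain carbon bound to a carbonyl carbon.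

Next is compound 3 `CCNCC(=O)Nc1cc(OC)ccc1C(=O)c1ccc(OC)c2c1C=CC(C)(C)O2`, which differs from compound 2 by ethyl in place of hydrogen on an amine nitrogen. Among the measured compounds shown here, no measured step covers substitution on this nitrogen. The nearest evidence is the change at the same chain end, which gave a 1.3-fold higher number from compound 1 to compound 2 (0.12 log units; within the scatter), so only a weak guide is available. No shift beyond the scatter is therefore expected in this assay, though the uncertainty is wide.

The expected change is a 1.0-fold higher number from compound 2 to compound 3 (0.02 log units; within the scatter).

The estimate for compound 3 is 1300 nM, with an expected range of 550 nM to 3000 nM.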

Compound 3, half-maximal inhibitory concentration: 7230 nM
Beside the measured number, compound 3's estimate is 5.6-fold (0.75 log units) below it; the measured number lies above the stated range.
By their numbers in this assay, from the lowest: compounds 1 and 2 (each within the scatter of the next); then compound 3.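

In this assay this amine nitrogen responds more to ethyl in place of hydrogen (a 5.8-fold higher number from compound 2 to compound 3 (0.76 log units; beyond the scatter)) than the chain end did to amino in place of hydroxy (a 1.3-fold higher number from compound 1 to compound 2 (0.12 log units; within the scatter)); only the first of these steps lies beyond the scatter. Set against the hydroxy end, the ethylamino end also stands beyond the scatter (a 7.7-fold higher number from compound 1 to compound 3 (0.89 log units; beyond the scatter)), so across these three compounds the change in the number appears only once ethyl is on the nitrogen. The data shown give no measured explanation for this step.

Open, as far as these compounds go, is how methyl, propyl or a second ethyl on this nitrogen, or a piperidine ring built on it, would compare with ethyl. With ethyl as the only substituent shown, no trend with chain length can be read.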